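The compounds below may be only part of what the source reports. "The series", "measured", "known", "first", "only" and "open" are said of these compounds alone.

Of the compounds shown here, three of one shared core have so far been tested in a functional assay on BT-549 cells (Homo sapiens) for inhibition, read by sulforhodamine B assay, with a stated time of 48 h; on this read-out higher numbers stand for weaker inhibition of growth and lower numbers for stronger inhibition of growth. Compound 2 `CCCCOc1ccc(NC(=O)n2nc(N)c3ccccc32)cc1` gives 14000 nM, the lowest of the two numbers available. Compound 3 `Nc1nn(C(=O)Nc2c(F)cccc2F)c2ccccc12` gives 28800 nM, a higher number whose gap to compound 2 lies beyond the usual scatter of repeat measurements. Compound 1 `COc1ccc(NC(=O)Nc2n[nH]c3ccccc23)cc1` is a different case: in this assay compound 1 gives > 100000 nM, which is a limit of the assay and not a number (the limit of > 100000 nM in this assay, at which 1 of the 3 values shown sits).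

The next compound, compound 4 `Nc1nn(C(=O)Nc2ccc(Cc3ccccc3)cc2)c2ccccc12`, is built from compound 2 by one change: benzyl in place of butoxy on an aromatic carbon. Among the compounds with values here, no measured pair in this set shows what such a swap does to the read-out, so there is no step to lean on. Since the shared core is kept and the exchanged group sits at the same place, only a small shift is expected, in either direction, and likely none beyond the scatter. For compound 4 the estimate is 11000 nM, within a range from 3500 nM to 35000 nM, which means an expected step of a 1.3-fold lower number from compound 2 to compound 4 (0.10 log units; within the scatter).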

Compound 4, concentration for 50% growth inhibition: 13500 nM
Compound 4: the middle estimate sits 1.2-fold (0.09 log units) below what was measured; the range from low to high includes it.
By their numbers in this assay, from the lowest: compounds 4 and 2 (each within the scatter of the next); then compound 3. At a limit, above all of these: compound 1.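

In this assay, putting benzyl in place of butoxy on an aromatic carbon, para to a large group, gives a 1.0-fold lower number from compound 2 to compound 4 (0.02 log units; within the scatter), so compound 2 and compound 4 cannot be told apart. Within the data shown here, this is the first sign of how this position responds: within this one pair, an open chain with an oxygen and a group carrying a six-membered aromatic ring of carbon only give matching read-outs, even though the hydrogen-bond acceptor of butoxy is gone. No measurement shown here explains why these two groups read alike.

Going by these compounds, whether a methyl, an amine, a carboxylic acid or a longer chain at this place would read the same remains open. Also open, on these data alone, is whether any group here can give a clearly lower number than compound 2 and compound 4 do.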